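Notes on the shared core: N-sulfonyl in place of benzyl

A few compounds are considered here, and "the series" means these few. Any claim that something is new, unique, unknown or untested is made for them only; others in the source may bear on it.

Measured so far:
compound 1 `COc1ccc(-c2cc(=O)c3c(OC)cc(OC)cc3n2Cc2ccccc2)cc1`: > 17300 nM
compound 2 `COc1ccc(-c2c(Br)c(=O)c3c(OC)cc(OC)cc3n2S(=O)(=O)c2ccc(OC)cc2)cc1`: > 20000 nM
compound 3 `COc1ccc(-c2cc(=O)c3c(OC)cc(OC)cc3n2S(=O)(=O)c2ccc(F)cc2)cc1`: > 65500 nM

In a functional assay on HepG2 cells (Homo sapiens) for antiproliferative activity, with a stated time of 72 h (on this read-out lower numbers stand for an effect already at smaller amounts and higher numbers for an effect only at larger amounts of compound), compound 1 gives > 17300 nM, which is a limit of the assay and not a number. Compound 2 gives > 20000 nM, again a limit. Compound 3 gives > 65500 nM, also a limit. Compound 1 therefore stands nowhere on a scale: it has only a limit, and the two further values are limits as well (the limit of > 17300 nM in this assay, at which 1 of the 3 values shown sits, (the limit of > 20000 nM in this assay, at which 1 of the 3 values shown sits), (the limit of > 65500 nM in this assay, at which 1 of the 3 values shown sits)).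

Going by the values given here, the one step between measured compounds that differ in a single place is a step that the two limits leave unreadable from compound 1 to compound 3, and the two limits leave its size unreadable.

Compound 4 `COc1ccc(-c2cc(=O)c3c(OC)cc(OC)cc3n2S(=O)(=O)c2cccc(Br)c2)cc1` differs from compound 1 as follows: (3-bromophenyl)sulfonyl in place of benzyl on an aromatic nitrogen. Among the compounds with values here, the only step bearing on this change is the one from compound 1 to compound 3, which could not be read, so no direction and no size can be taken from the data; the expected step that the limit leaves unreadable from compound 1 to compound 4 is stated as a placeholder rather than a finding. For compound 4 the value in this assay is estimated at 40000 nM, with a range from 15000 nM to 120000 nM, and most likely the assay will again report only a limit.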

Compound 4, half-maximal effective concentration: > 58600 nM
Compound 4 was reported as a limit; the forecaster's own chance of this, stated with the estimate: 85%; at least 1.4-fold (0.16 log units) between middle value and limit.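

In this assay compound 4 gives > 58600 nM, a limit of the assay and not a number. The steps linking compound 4 to compound 1 and to compound 3 join limits only and cannot be read. The compounds shown leave open how benzyl, (4-fluorophenyl)sulfonyl and (3-bromophenyl)sulfonyl rank in this read-out, and whether any of them gives a measurable value.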